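Aryl swap on the triazole of compound 2

This account rests on a few compounds, and the source may have more. Where it says the series, first, only, none or still open, it means among the compounds named here.

Measured compounds:
Compound 1 `Cc1ccc(S(=O)(=O)Oc2ccc3c(c2C)[C@H](Cn2cc(-c4ccc(Cl)cc4)nn2)[C@@]24CC(=O)[C@@](C)(CC[C@@H]32)C4)cc1`. In a functional assay on A549 cells (Homo sapiens) for cytotoxicity, read by MTT assay, with a stated time of 4 days (a higher number here means a weaker inhibitor, a lower number a stronger inhibitor), compound 1 gives > 20000 nM, which is a limit of the assay and not a number.
Compound 2 `Cc1ccc(S(=O)(=O)Oc2ccc3c(c2C)[C@H](Cn2cc(-c4ccccn4)nn2)[C@@]24CC(=O)[C@@](C)(CC[C@@H]32)C4)cc1`. In this assay compound 2 gives > 20000 nM, again a limit.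
Compound 3 `Cc1c(O)ccc2c1[C@H](Cn1cc(-c3ccccn3)nn1)[C@@]13CC(=O)[C@@](C)(CC[C@@H]21)C3`. In this assay compound 3 gives > 20000 nM, also a limit.

Compound 2 therefore stands among the values shown only as a limit, and (the limit of > 20000 nM in this assay, at which 3 of the 3 values shown sit). The step that the two limits leave unreadable from compound 1 to compound 2 and the step that the two limits leave unreadable from compound 2 to compound 3 both join two limits, so neither shows how far any of these compounds lies beyond the limit.

Compound 4 `Cc1ccc(-c2cn(C[C@H]3c4c(ccc(OS(=O)(=O)c5ccc(C)cc5)c4C)[C@@H]4CC[C@@]5(C)C[C@]43CC5=O)nn2)cc1` carries the change (4-methylphenyl in place of pyridin-2-yl on an aromatic carbon). Among the compounds with values here, the measured steps that bear on it are the two through compound 2, and both are unreadable; no measured step gives a readable size in either direction. Nothing in the numbers shown points to compound 4 moving inside the measurable range.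

The expected step is a step that the limit leaves unreadable from compound 2 to compound 4, estimated as no readable change. Compound 4 is expected at 25000 nM, in the range 8000 nM to 80000 nM, most likely reported once more as a limit.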

Compound 4, half-maximal inhibitory concentration: > 20000 nM
Compound 4 ended at the assay's limit (the forecaster's own chance of this, stated with the estimate: 80%); the middle value is on the limit's open side.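

Neither the step from compound 2 to compound 4 nor the step from compound 1 to compound 4 can be read, as both join two limits: the limit of > 20000 nM in this assay, at which 4 of the 4 values shown sit.

The compounds shown leave open how far any of them lies beyond the limit, and which change to the shared core, if any, would bring a value into the measurable range.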